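Trifluoromethylphenyl replaces acetylphenyl on a pair with level low inhibition numbers

The compounds below may be only part of what the source reports. "The series", "measured", "known", "first", "only" and "open" are said of these compounds alone.

Measured compounds:
compound 1 `Brc1cn2ccnc2c(-c2ccc3ncn(C4CCCCC4)c3c2)n1`: 4.92%
compound 2 `CC(=O)c1ccc(-c2cn3ccnc3c(-c3ccc4ncn(C5CCCCC5)c4c3)n2)cc1`: 6.38%

In a functional assay on OVCAR-8 cells (Homo sapiens) for inhibition, read by sulforhodamine B assay, with a stated time of 48 h, tested at 10 uM (on this read-out lower numbers stand for less inhibition and higher numbers for more inhibition at the one concentration tested (going by the name of the read-out)), compound 1 gives 4.92%, and in the same assay compound 2 gives 6.38%. Within the data shown here, compound 2 thus stands alongside compound 1 rather than apart from it: the only measured step, a number 1.5 percentage points higher from compound 1 to compound 2 (within the scatter), does not leave the scatter, so the two numbers are to be read as the same low level of inhibition.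

Compound 3 `FC(F)(F)c1cccc(-c2cn3ccnc3c(-c3ccc4ncn(C5CCCCC5)c4c3)n2)c1` differs from compound 2 in one place: 3-(trifluoromethyl)phenyl in place of 4-acetylphenyl on an aromatic carbon. Among the measured compounds shown here, the one step that bears on this change is a number 1.5 percentage points higher from compound 1 to compound 2 (within the scatter), which exchanged bromo for 4-acetylphenyl at this position without moving the read-out beyond the scatter. That step is not a direct match, since it did not exchange one aryl group for another, but it gives no sign that this position steers the read-out. The step from compound 2 to compound 3 is therefore expected to be a number 1.6 percentage points higher from compound 2 to compound 3 (within the scatter), that is, nothing beyond the scatter in either direction. Compound 3 is estimated at 8%, within a range from -6% to 24%.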

Compound 3, a percentage reported as inhibition, at one concentration (the size of the read-out at that concentration, not a potency): 10.1%
For compound 3 the middle estimate is 2.1 percentage points below the measured one; the measured number falls inside the stated range.
By their numbers in this assay, from the lowest: compounds 1, 2 and 3 (each within the scatter of the next).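

In this assay, exchanging one aryl group for another at this position gives a number 3.7 percentage points higher from compound 2 to compound 3 (within the scatter), and exchanging bromo for the same aryl group gives a number 5.2 percentage points higher from compound 1 to compound 3 (within the scatter). The earlier pair compared bromo with a single aryl group, whereas the three compounds now show that bromo, 4-acetylphenyl and 3-(trifluoromethyl)phenyl cannot be told apart on this read-out, even though the hydrogen-bond acceptor of 4-acetylphenyl is absent from the entering group and the two aryl groups carry their substituents at different places. No measurement is available to account for this level reading.

The compounds shown leave open whether any group at this position can raise inhibition beyond the scatter, for instance a morpholine, a primary amine or a carboxylic acid in place of the aryl ring. They also leave open whether the cyclohexyl group, which all three compounds share, has any bearing on the read-out, since a change there, such as a methyl group in its place, would be needed to tell.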